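Stilbene Anilines Versus Phenols in a Cell Inhibition Assay

This account rests on a few compounds, and the source may have more. Where it says the series, first, only, none or still open, it means among the compounds named here.

The measured compounds and their values:
compound 1, `COc1cccc(/C=C/c2ccccc2O)c1`, 20 ug/mL
compound 2, `COc1ccccc1/C=C/c1cccc(O)c1`, 24 ug/mL
compound 3, `COc1cccc(/C=C/c2ccccc2N)c1`, 0.5 ug/mL

The three compounds were tested in an ADME assay on HEK293 cells (Homo sapiens) for inhibition, read by MTT assay, with a stated time of 2 days; a higher number here means a weaker inhibitor, a lower number a stronger inhibitor. Compound 1 and compound 2 share the same atoms joined differently; the difference between the two cores is not broken down here. Their numbers, 20 ug/mL for compound 1 and 24 ug/mL for compound 2, lie within the scatter of each other.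

Compound 3 differs from compound 1 by amino in place of hydroxy on an aromatic carbon. This change made a large step: a 40-fold lower number from compound 1 to compound 3 (1.60 log units; beyond the scatter).

Compound 4, `COc1ccccc1/C=C/c1cccc(N)c1`, has not yet been measured. It differs from compound 2 by amino in place of hydroxy on an aromatic carbon. This is the same kind of change as that from compound 1 to compound 3, not the same: in compound 3 the amino sits ortho to a large group, in compound 4 it sits meta to a large group.

Because the change from compound 1 to compound 3 gave a 40-fold lower number from compound 1 to compound 3 (1.60 log units; beyond the scatter), and because the starting point of compound 1 is near that of compound 2, with compound 2 at 24 ug/mL, a step of a similar size is expected from compound 2 to compound 4, namely a 24-fold lower number from compound 2 to compound 4 (1.38 log units; beyond the scatter). The different placing of the amino leaves the size uncertain, so the range is wide. Compound 4 is therefore estimated at 1 ug/mL in this assay, expected between 0.3 ug/mL and 4 ug/mL.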

Compound 4, half-maximal inhibitory concentration: 45 ug/mL
The estimate for compound 4 lay 45-fold (1.65 log units) below the measured number; measured number outside the range, above it.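

Among the compounds shown here, on the core of compound 2, amino in place of hydroxy on an aromatic carbon gave in this assay a 1.9-fold higher number from compound 2 to compound 4 (0.27 log units; within the scatter), so this exchange, which had a large effect on the core of compound 1, produced no step that can be told from the scatter here. The change therefore does not carry over from one core to the other in this series, and its effect depends on the core that carries it: the same change on two cores in this assay, a 40-fold lower number (1.60 log units; beyond the scatter) from compound 1 to compound 3 and a 1.9-fold higher number (0.27 log units; within the scatter) from compound 2 to compound 4, 75-fold (1.88 log units) apart, beyond the scatter of two such steps

This does not show which difference between the two cores accounts for the gap, since the amino of compound 4 sits meta to a large group and the rest of the structure is also joined differently, and two cores give no rule for any third.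

The compounds shown leave open whether the gap follows the place of the amino or the arrangement of the rest of the core, which a compound with only one of these altered could separate. They also leave open whether a methylamino group or an acetamide in the same place would behave like the amino of compound 3, at 0.5 ug/mL, or like that of compound 4, at 45 ug/mL.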